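A few compounds are considered here, and "the series" means these few. Any claim that something is new, unique, unknown or untested is made for them only; others in the source may bear on it.

Compound 1 `Fc1ccc(-c2cn3ccnc3c(-c3ccc4ncn(C5CCCCC5)c4c3)n2)cc1`: 9.82%
Compound 2 `CC(=O)c1ccc(-c2cn3ccnc3c(-c3ccc4ncn(C5CCCCC5)c4c3)n2)cc1`: 0.58%

Of the compounds shown here, two sharing one core have been measured in a functional assay on SK-MEL-2 cells (Homo sapiens) for inhibition, read by sulforhodamine B assay, with a stated time of 48 h, tested at 10 uM; on this read-out lower numbers stand for less inhibition and higher numbers for more inhibition at the one concentration tested (going by the name of the read-out). Compound 1 gives 9.82% and compound 2 gives 0.58%. On the numbers shown, compound 1 carries the larger figure of the two, but the only step so far, a number 9.2 percentage points lower from compound 1 to compound 2 (within the scatter), is within the scatter, so the two compounds cannot be separated by this assay, and both inhibit weakly at the single concentration tested.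

Compound 3 `COc1ccccc1-c1cn2ccnc2c(-c2ccc3ncn(C4CCCCC4)c3c2)n1` is the next member. It differs from compound 1 by 2-methoxyphenyl in place of 4-fluorophenyl on an aromatic carbon. Among the measured compounds shown here, the one measured step, from compound 1 to compound 2, changed the group at the same aryl ring and moved the read-out by a number 9.2 percentage points lower from compound 1 to compound 2 (within the scatter), a change that did not rise above the scatter. For the measured compounds named here, no measured pair shows 2-methoxyphenyl in place of 4-fluorophenyl itself. With only that single, flat step to lean on, compound 3 is expected to show no movement beyond the scatter in this assay, that is, a step of about a number 2.8 percentage points lower from compound 1 to compound 3 (within the scatter). Compound 3 is therefore estimated at 7%, with a range from -5% to 22%.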

Compound 3, a percentage reported as inhibition, at one concentration (the size of the read-out at that concentration, not a potency): 12.1%
For compound 3 the middle estimate is 5.1 percentage points below the measured one, within the range that was stated.
By their numbers in this assay, from the lowest: compounds 2, 1 and 3 (each within the scatter of the next, the first and the last beyond it).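

In this assay, exchanging 4-fluorophenyl for 2-methoxyphenyl on this aromatic carbon gives a number 2.3 percentage points higher from compound 1 to compound 3 (within the scatter), so this position takes a group with a different substituent and substitution pattern on the phenyl ring without a change that can be told from the scatter. The same position also yields the first separation in the series, with a number 11.5 percentage points higher from compound 2 to compound 3 (beyond the scatter), although this step is modest, compound 3 stands at only 12.1%, and compound 1 cannot be separated from either of the other two compounds. Nothing available explains why the 2-methoxyphenyl and 4-acetylphenyl compounds separate while the other pairs do not.

The compounds shown leave open whether a phenyl ring bearing an amine or a carboxylic acid at this position would raise the inhibition well beyond these low figures. They also do not settle whether the gap between compound 2 and compound 3 comes from the methoxy group, the acetyl group or the place each occupies on the phenyl ring, since these differ together in that pair.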